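A few compounds are considered here, and "the series" means these few. Any claim that something is new, unique, unknown or untested is made for them only; others in the source may bear on it.

Measured in a functional assay on MDA-MB-231 cells (Homo sapiens) for antiproliferative activity, with a stated time of 48 h (a higher number here means a weaker inhibitor, a lower number a stronger inhibitor), all three values being limits:
- compound 1 `CC(=O)c1ccc(-c2ccc(N3CCCC3)nn2)cc1`: > 25000 nM
- compound 2 `CCN(CC)c1ccc(-c2cccc(Cl)c2)nn1`: > 25000 nM
- compound 3 `CCN(CC)c1ccc(-c2ccc(C#N)cc2)nn1`: > 25000 nM

Compound 3 reads > 25000 nM, which is a limit and not a number. Among the measured compounds shown here, the set as a whole stands at the limit of > 25000 nM in this assay, at which 3 of the 3 values shown sit, and no step between measured compounds is available. Compound 4 `CCN(CC)c1ccc(-c2ccc(C(C)=O)cc2)nn1` has acetyl in place of cyano on an aromatic carbon of compound 3, para to a large group: acetyl in place of cyano on an aromatic carbon. Compound 1 also carries acetyl and reads > 25000 nM, likewise a limit. No step beyond the scatter is expected in this assay. The estimated change is a step that the limit leaves unreadable from compound 3 to compound 4. For compound 4 the expected value is 30000 nM, with an estimated range of 12000 nM to 60000 nM.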

Compound 4, half-maximal inhibitory concentration: 5000 nM
Estimate against measurement, compound 4: 6.0-fold (0.78 log units) above; the whole stated range lies above it.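

In this assay, the aromatic carbon para to a large group responds to the change: acetyl in place of cyano gives an at least 5.0-fold lower number from compound 3 to compound 4 (0.69 log units; beyond the scatter). Acetyl alone is not enough, as diethylamino in place of pyrrolidin-1-yl gives an at least 5.0-fold lower number from compound 1 to compound 4 (0.69 log units; beyond the scatter), so among these compounds activity appears only with acetyl and diethylamino together. Compound 4 is the only compound with a readable value: the limit of > 25000 nM in this assay, at which 3 of the 4 values shown sit.

As far as these compounds go, both steps start from a limit, so their full size stays open. Also open, from the compounds shown here alone, is how a carboxylic acid at this carbon, or piperidin-1-yl in place of diethylamino, would read.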